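A few compounds are considered here, and "the series" means these few. Any claim that something is new, unique, unknown or untested is made for them only; others in the source may bear on it.

Three compounds share one core and have been measured in an assay on isolated protein for displacement of a labelled ligand from metabotropic glutamate receptor 5 (Homo sapiens), with a stated time of 60 min, tested at 1 uM; a lower number here means less inhibition, a higher number more inhibition at the concentration tested (going by the name of the read-out):

Compound 1 `COc1ccc(S(=O)(=O)c2cnc3cc(F)ccc3c2N2CCC(C)CC2)cc1` gives 90%
Compound 2 `Cc1ccc(S(=O)(=O)c2cnc3cc(F)ccc3c2N2CCC(C)CC2)cc1Cl` gives 93%
Compound 3 `CC1CCN(c2c(S(=O)(=O)c3ccc(C#N)cc3)cnc3cc(F)ccc23)CC1` gives 83%

The three numbers lie close together. The step of a number 7 percentage points lower from compound 1 to compound 3 (within the scatter) and the step of a number 10 percentage points lower from compound 2 to compound 3 (within the scatter) are both within the scatter, so compound 3 cannot be told apart from the other two on these numbers. Compound 4 `CC1CCN(c2c(S(=O)(=O)c3ccccc3)cnc3cc(F)ccc23)CC1` has not yet been measured in this assay. It differs from compound 3 in one place: hydrogen in place of cyano on an aromatic carbon. The measured steps that bear on this are those that exchanged the group on the same phenyl ring: a number 7 percentage points lower from compound 1 to compound 3 (within the scatter), a number 10 percentage points lower from compound 2 to compound 3 (within the scatter) and a number 3 percentage points higher from compound 1 to compound 2 (within the scatter), every one of them within the scatter. Exchanging that group has so far left the read-out in this assay essentially unchanged, so no step beyond the scatter is expected here either. The step from compound 3 to compound 4 is estimated as a number 2 percentage points higher from compound 3 to compound 4 (within the scatter). Compound 4 is therefore expected to give about 85%, with a range from 70% to 96%.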

Compound 4, a percentage reported as inhibition, at one concentration (the size of the read-out at that concentration, not a potency): 87%
Beside the measured number, compound 4's estimate is 2 percentage points below it; the range from low to high includes it.
By their numbers in this assay, from the lowest: compounds 3, 4, 1 and 2 (each within the scatter of the next).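

Compound 4 has no group on the phenyl ring at the place where compounds 1 and 3 carry one, so it gives a bare-ring reference in this assay: hydrogen in place of cyano gives a number 4 percentage points higher from compound 3 to compound 4 (within the scatter) and hydrogen in place of methoxy gives a number 3 percentage points lower from compound 1 to compound 4 (within the scatter) while phenyl in place of 3-chloro-4-methylphenyl gives a number 6 percentage points lower from compound 2 to compound 4 (within the scatter) and these steps are all within the scatter. The bare phenyl therefore cannot be told apart from any of the three substituted rings, and none of those groups is needed to keep the read-out at this level in these four compounds. No measurement at hand explains this result.

As far as these compounds go, whether an amine, a carboxylic acid or a longer chain such as butoxy at this place would also leave the read-out unchanged stays open. A read-out at one concentration is also not a potency, so real differences in potency among these four compounds could remain hidden.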